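The source may hold more compounds than are shown below. What is called first, only, known or untested is meant among the compounds shown, and "the series" means these compounds.

Measured in a functional assay on U2OS cells for antagonist activity at proto-oncogene Wnt-3 (Homo sapiens), read by a luciferase reporter, with a stated time of 18 h; on this read-out lower numbers stand for an effect already at smaller amounts and higher numbers for an effect only at larger amounts of compound:

compound 1 `CN(C)CC(=O)N1CCC(NS(=O)(=O)c2cc(S(=O)(=O)c3ccccc3)ccc2C(F)(F)F)CC1` — 280 nM
compound 2 `CC(=O)N1CCC[C@H]1C(=O)N1CCC(NS(=O)(=O)c2cc(S(=O)(=O)c3ccccc3)ccc2C(F)(F)F)CC1` — 250 nM
compound 3 `CN(C)CC(=O)N1CCC[C@H]1C(=O)N1CCC(NS(=O)(=O)c2cc(S(=O)(=O)c3ccccc3)ccc2C(F)(F)F)CC1` — 310 nM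

All three share the same core and differ only in the group on the carbonyl carbon of the piperidine amide. The measured steps are small: a 1.1-fold lower number from compound 1 to compound 2 (0.05 log units; within the scatter), a 1.1-fold higher number from compound 1 to compound 3 (0.04 log units; within the scatter) and a 1.2-fold higher number from compound 2 to compound 3 (0.09 log units; within the scatter). Compound 3 therefore stands close to compound 1 and to compound 2, and nothing separates the three beyond the scatter.

Compound 4 `O=C([C@@H]1CCCN1Cc1ccccc1)N1CCC(NS(=O)(=O)c2cc(S(=O)(=O)c3ccccc3)ccc2C(F)(F)F)CC1` is not yet measured. It differs from compound 3 as follows: benzyl in place of ((dimethylamino)methyl)carbonyl on an amine nitrogen in a ring.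

Of the measured steps, only those touching the substituent on the amine nitrogen in the ring bear on this change: a 1.2-fold higher number from compound 2 to compound 3 (0.09 log units; within the scatter) exchanged hydrogen for dimethylamino on the chain carbon bound to that carbonyl, and a 1.1-fold higher number from compound 1 to compound 3 (0.04 log units; within the scatter) added the whole 1-(((dimethylamino)methyl)carbonyl)pyrrolidin-2-yl unit. Both stayed within the scatter. Among the compounds with values here, no measured step removes the carbonyl from that nitrogen or brings in a benzyl, so the present data give no direction for this step; the working expectation is a step no larger than the scatter, a 1.0-fold lower number from compound 3 to compound 4 (0.01 log units; within the scatter). Compound 4 is thus estimated at 300 nM, with a range from 120 nM to 800 nM.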

Compound 4, half-maximal effective concentration: 720 nM
Compound 4: middle estimate off by 2.4-fold (0.38 log units), on the low side; measured number inside the range.
By their numbers in this assay, from the lowest: compounds 2, 1 and 3 (each within the scatter of the next); then compound 4.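

Within the data shown here, the amine nitrogen in the five-membered non-aromatic ring is the first place where a change carries the number in this assay beyond the scatter: benzyl in place of ((dimethylamino)methyl)carbonyl gives a modest rise (a 2.3-fold higher number from compound 3 to compound 4 (0.37 log units; beyond the scatter)), and benzyl in place of acetyl gives one in the same direction (a 2.9-fold higher number from compound 2 to compound 4 (0.46 log units; beyond the scatter)). The earlier changes on the carbonyl-bearing side of this nitrogen all stayed within the scatter, whereas the wider exchange that also brings in benzyl moves the number beyond it too (a 2.6-fold higher number from compound 1 to compound 4 (0.41 log units; beyond the scatter)), so the series tolerates these carbonyl-bearing groups more evenly than it tolerates benzyl here. No measurement at hand accounts for this shift.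

Still open, from the compounds shown here alone, is whether the higher number goes with the aromatic ring of benzyl or with the absence of a carbonyl on that nitrogen, and a benzoyl group, which holds both a carbonyl and an aromatic ring, would separate the two. A plain methyl group or a free secondary amine at the same nitrogen would show whether compound 4 marks a general trend for groups without a carbonyl there.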